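Ethynyl for 4-fluorophenyl on the shared core

This account rests on a few compounds, and the source may have more. Where it says the series, first, only, none or still open, it means among the compounds named here.

Measured compounds:
compound 1 `COc1ccccc1NC(=O)c1cc(=O)[nH]c2cc(Br)ccc12` — > 20000 nM
compound 2 `O=C(Nc1cc(F)cc(F)c1)c1cc(=O)[nH]c2cc(O)ccc12` — > 20000 nM
compound 3 `O=C(Nc1cccc(F)c1)c1cc(=O)[nH]c2cc(-c3ccc(F)cc3)ccc12` — 10300 nM

In a functional assay on KYSE-410 cells (Homo sapiens) for antiproliferative activity, read by MTT assay, with a stated time of 72 h (a lower number here means a stronger inhibitor, a higher number a weaker inhibitor), compound 1 gives > 20000 nM, which is a limit of the assay and not a number. Compound 2 likewise gives > 20000 nM, again a limit. Within the data shown here, compound 3 gives 10300 nM in this assay, the only actual number among the three; the other two values sit at the limit of > 20000 nM in this assay, at which 2 of the 3 values shown sit. Compound 3 is therefore the reference point, though a weak inhibitor on its own terms.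

Compound 4 `C#Cc1ccc2c(C(=O)Nc3cccc(F)c3)cc(=O)[nH]c2c1` has not yet been measured in this assay. It differs from compound 3 by ethynyl in place of 4-fluorophenyl on an aromatic carbon. Among the measured compounds shown here, no pair of measured compounds differs in a single place, so the set itself gives no measured step to lean on for this change. The expectation is a step of modest size, toward a weaker inhibitor, or none beyond the scatter. Compound 4 is expected to give about 15000 nM in this assay, within 5000 nM to 40000 nM. That estimate corresponds to an expected 1.5-fold higher number from compound 3 to compound 4 (0.16 log units; within the scatter).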

Compound 4, half-maximal inhibitory concentration: 9700 nM
Compound 4: middle estimate off by 1.5-fold (0.19 log units), on the high side, and the stated range covers the measured number.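

In this assay, ethynyl in place of 4-fluorophenyl gives a 1.1-fold lower number from compound 3 to compound 4 (0.03 log units; within the scatter). Among these compounds, this is the first single-place step, and it shows that at this aromatic carbon the 7 heavy atoms and the ring of 4-fluorophenyl can give way to the 2 heavy atoms of ethynyl with the two values staying within the scatter. Compound 1 and compound 2 add no further step at this position, and their values are limits of the assay, not numbers: the limit of > 20000 nM in this assay, at which 2 of the 4 values shown sit.

The compounds shown leave open whether an amine, a carboxylic acid or a longer chain on this aromatic carbon would read apart from compound 3 and compound 4. They also leave open whether the same step would hold with another group on the amide nitrogen.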